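This account rests on a few compounds, and the source may have more. Where it says the series, first, only, none or still open, it means among the compounds named here.

Working notes on the series.

Among the compounds with values here, compound 1 `CC[C@@H]1C(=O)N(C)c2cnc(-n3ccc4cc(F)ccc43)nc2N1C1CCCC1` sits at the high end of the three numbers so far: in an assay for inhibition of serine/threonine-protein kinase PLK2 (Homo sapiens), read by FRET and Z'-LYTE, with a stated time of 1 h (a higher number here means a weaker inhibitor, a lower number a stronger inhibitor), compound 1 gives 969 nM. Compound 2 `CC[C@@H]1C(=O)N(C)c2cnc(Nc3ccc(S(=O)(=O)NCCO)cc3)nc2N1C1CCCC1` gives 7.86 nM in this assay, and compound 3 `CCC1C(=O)N(C)c2cnc(Nc3ccc(S(=O)(=O)NC)cc3)nc2N1c1ccn(C)n1` gives 71.6 nM; both of these lie well beyond the scatter from compound 1, so compound 1 is the weakest inhibitor of the three. Within the data shown here, compounds 2 and 3 differ from compound 1 in more than one place, so no single step between measured compounds is available to lean on.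

Compound 4 `CCCNC(=O)c1ccc2c(ccn2-c2ncc3c(n2)N(C2CCCC2)[C@H](CC)C(=O)N3C)c1` has not yet been measured in this assay. It keeps the core of compound 1 and changes one substituent: propylcarbamoyl in place of fluoro on an aromatic carbon. Among the measured compounds shown here, no measured pair shows this change, so the direction is not fixed by the data. The expectation for compound 4 is a modest gain in inhibition, a step from compound 1 of about a 2.4-fold lower number from compound 1 to compound 4 (0.38 log units; beyond the scatter), with the possibility that the change stays within the scatter. Compound 4 is therefore estimated at 400 nM in this assay, expected to fall between 100 nM and 2000 nM.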

Compound 4, half-maximal inhibitory concentration: 11.4 nM
The estimate for compound 4 lay 35-fold (1.55 log units) above the measured number, outside the stated range (below it).
By their numbers in this assay, from the lowest: compounds 2 and 4 (each within the scatter of the next); then compound 3; then compound 1.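

In this assay, within the data shown here, the first single-place step, an 85-fold lower number from compound 1 to compound 4 (1.93 log units; beyond the scatter), shows that this aromatic carbon of the fused system strongly affects the number. It also shows that a group of many more heavy atoms than fluoro, carrying a hydrogen-bond donor and acceptor, is compatible with strong inhibition here. No measurement available bears on why the step is so large.

The change brings in the carbonyl, the amide hydrogen and the propyl chain together, so the compounds shown leave open which of these parts accounts for the step. Also open, as far as these compounds go, is how the number would respond at this same carbon to a carboxylic acid, an amine, or a carbamoyl group with a methyl or a longer chain on its nitrogen.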